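A few compounds are considered here, and "the series" means these few. Any claim that something is new, unique, unknown or untested is made for them only; others in the source may bear on it.

Compound 1 `Nc1nc(Cl)c2ncn(Cc3ccc(CCl)cc3)c2n1`: 8130 nM
Compound 2 `ClCc1cccc(Cn2cnc3c(Cl)nc(Cl)nc32)c1`: 1820 nM
Compound 3 `ClCc1ccc(Cn2cnc3c(Cl)nc(Cl)nc32)cc1`: 1820 nM

Of the compounds shown here, three have been measured in a functional assay on KM12 cells (Homo sapiens) for cytotoxicity, read by sulforhodamine B assay, with a stated time of 48 h; on this read-out higher numbers stand for weaker inhibition of growth and lower numbers for stronger inhibition of growth. Compound 2 and compound 3 are built from the same atoms joined differently; the difference between the two cores is not broken down here. In this assay compound 2 gives 1820 nM and compound 3 gives 1820 nM, identical at the digits recorded, a gap that lies within the usual scatter of repeated measurements. Compound 1 differs from compound 3 in one place: amino in place of chloro on an aromatic carbon. That single change carried a 4.5-fold higher number from compound 3 to compound 1 (0.65 log units; beyond the scatter), a modest weakening of growth inhibition that is beyond the scatter.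

Compound 4 `Nc1nc(Cl)c2ncn(Cc3cccc(CCl)c3)c2n1` has not yet been measured. It stands to compound 2 exactly as compound 1 stands to compound 3; the difference is amino in place of chloro on an aromatic carbon, the same change at a place described in the same words. Given that compound 2 and compound 3 give the same number, and that the one measured example of this change is a 4.5-fold higher number from compound 3 to compound 1 (0.65 log units; beyond the scatter), the step from compound 2 to compound 4 is expected to be of about the same size, a 4.5-fold higher number from compound 2 to compound 4 (0.65 log units; beyond the scatter), though a single example is thin support. On that basis compound 4 is estimated to give around 8100 nM in this assay, with the expected range running from 4000 nM to 16500 nM.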

Compound 4, concentration for 50% growth inhibition: 3310 nM
Compound 4: the middle estimate sits 2.4-fold (0.39 log units) above what was measured; measured number outside the range, below it.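

In this assay, putting amino in place of chloro gives a 1.8-fold higher number from compound 2 to compound 4 (0.26 log units; within the scatter), so on this core the swap cannot be told apart from the ordinary variation between repeated measurements, while on the core of compound 3 it gives a 4.5-fold higher number from compound 3 to compound 1 (0.65 log units; beyond the scatter), which can. Those results may look different when read one at a time, but set side by side they do not differ by more than two such steps can be expected to: the same change on two cores in this assay, a 4.5-fold higher number (0.65 log units; beyond the scatter) from compound 3 to compound 1 and a 1.8-fold higher number (0.26 log units; within the scatter) from compound 2 to compound 4, 2.5-fold (0.39 log units) apart, within the scatter of two such steps. This shows that the change can be carried from one core to the other with no detectable difference in the size of its step, but it does not show that the step is truly the same on both, and two pairs of compounds in one assay are too few to establish a rule for the series.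

What a methylamino or methoxy group would do on that same aromatic carbon remains open, so the shown pairs say nothing about any replacement for chloro other than amino. Also open, going by these compounds, is how the numbers would move if a hydroxymethyl group stood in place of the chloromethyl group that all four compounds carry.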